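This account rests on a few compounds, and the source may have more. Where it says the series, first, only, none or still open, it means among the compounds named here.

Compound 1, whose structure is `COc1cc(-c2cc(C(=O)O)c3ccccc3n2)ccc1OCC(=O)Nc1ccccc1C`, gives 230000 nM in an ADME assay on HaCaT cells (Homo sapiens) for inhibition (a higher number here means a weaker inhibitor, a lower number a stronger inhibitor), the lowest of the two numbers shown. Compound 2, `COc1cc(-c2cc(C(=O)O)c3ccccc3n2)ccc1OCC(=O)Nc1ccc(F)cc1`, gives 286000 nM, and the step of a 1.2-fold higher number from compound 1 to compound 2 (0.09 log units; within the scatter). Compound 3, `COc1cc(-c2cc(C(=O)O)c3ccccc3n2)ccc1OCC(=O)NCc1ccccc1`, is reported only as a limit of the measurement, > 300000 nM. The step of an at least 1.3-fold higher number from compound 1 to compound 3 (0.11 log units; that floor lies within the scatter), and the step of an at least 1.0-fold higher number from compound 2 to compound 3 (0.02 log units; that floor lies within the scatter).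

Compound 4, `COc1cc(-c2cc(C(=O)O)c3ccccc3n2)ccc1OCC(=O)NCc1cccs1`, has not yet been measured. It differs from compound 1 in one place: (thiophen-2-yl)methyl in place of 2-methylphenyl on an amide-type nitrogen. The closest measured step is that from compound 1 to compound 3, where a benzyl group also entered on the amide-type nitrogen in place of 2-methylphenyl, and the number rose at most modestly. Both measured steps that replaced the 2-methylphenyl group stayed within the scatter, so in this assay no change beyond the scatter is expected, or at most a slight rise toward the limit. For compound 4 the expected value is 280000 nM, with a range from 150000 nM to 600000 nM, which corresponds to an expected step of a 1.2-fold higher number from compound 1 to compound 4 (0.09 log units; within the scatter).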

Compound 4, half-maximal inhibitory concentration: > 300000 nM
Compound 4 ended at the assay's limit (the forecaster's own chance of this, stated with the estimate: 45%); middle value at least 1.0-fold (0.02 log units) away from the limit.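

Compound 4 also stands only as a limit of the measurement: the limit of > 300000 nM in this assay, at which 2 of the 4 values shown sit.

The steps are an at least 1.3-fold higher number from compound 1 to compound 4 (0.11 log units; that floor lies within the scatter) and an at least 1.0-fold higher number from compound 2 to compound 4 (0.02 log units; that floor lies within the scatter), so a five-membered aromatic ring with sulfur on the saturated chain carbon does not bring a change beyond the scatter into view at this position. Compound 3 and compound 4 both sit at that limit, and the step between them cannot be read, so swapping phenyl for thiophen-2-yl gives no measurable difference here.

On these data alone, how far compound 3 and compound 4 lie past the limit remains unknown. Also open, as far as these compounds go, is whether a longer chain on the amide-type nitrogen, or an amine on the ring carried there, would give a number clearly lower than that of compound 1, 230000 nM.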